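From Hydroxy to 2-Aminophenyl at the Chain End

A few compounds are considered here, and "the series" means these few. Any claim that something is new, unique, unknown or untested is made for them only; others in the source may bear on it.

In a functional assay on MV4-11 cells (Homo sapiens) for antiproliferative activity, read by CCK-8 assay, with a stated time of 72 h (a higher number here means a weaker inhibitor, a lower number a stronger inhibitor), compound 1 `Cn1cc(-c2ccccc2Oc2ccccc2)c2cc(C(=O)NCCCCCCC(=O)NO)[nH]c2c1=O` gives 180 nM and compound 2 `Cn1cc(-c2ccccc2Oc2ccccc2)c2cc(C(=O)NCCCCCC(=O)NO)[nH]c2c1=O` gives 610 nM, the higher of the two numbers, which makes compound 2 the weaker inhibitor of this pair. Compound 3 `Cn1cc(-c2ccccc2Oc2ccccc2)c2cc(C(=O)NCCCCCC(=O)Nc3ccccc3N)[nH]c2c1=O` keeps the core and chain of compound 2 and differs only at the chain end: 2-aminophenyl in place of hydroxy on an amide-type nitrogen. Here, 2-aminophenyl stands in place of hydroxy on an amide-type nitrogen, so hydroxycarbamoyl becomes (2-aminophenyl)carbamoyl.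

Among the compounds with values here, only one measured step bears on this change: a 3.4-fold higher number from compound 1 to compound 2 (0.53 log units; beyond the scatter). Within the data shown here, that step kept the hydroxycarbamoyl group, so no measurement yet tests the new group directly. It does show that the numbers in this assay can move beyond the scatter after a small edit to this chain. The edit in compound 3 replaces more of the molecule, so a step beyond the scatter is expected, tentatively toward a higher number and with wide uncertainty. The expected change is a 2.5-fold higher number from compound 2 to compound 3 (0.39 log units; beyond the scatter). For compound 3, the estimated value is 1500 nM, with an expected range from 350 nM to 6000 nM.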

Compound 3, half-maximal inhibitory concentration: 70 nM
The estimate for compound 3 lay 21-fold (1.33 log units) above the measured number, and the stated range ends above it.
By their numbers in this assay, from the lowest: compound 3; then compound 1; then compound 2.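

In this assay the change at the chain end gives an 8.7-fold lower number from compound 2 to compound 3 (0.94 log units; beyond the scatter) and so moves the number down, while the earlier step between compound 1 and compound 2 altered only the chain and kept hydroxycarbamoyl throughout. This shows that the amide-type nitrogen at the chain end can carry 2-aminophenyl, with its seven heavy atoms and aromatic ring, in place of the single oxygen of hydroxy without any loss in this assay. The new group also outdoes the best hydroxycarbamoyl compound shown, with a 2.6-fold lower number from compound 1 to compound 3 (0.41 log units; beyond the scatter) despite the shorter chain of compound 3, and no information on why the number falls in this way is available.

As far as these compounds go, it remains open whether (2-aminophenyl)carbamoyl would give a still lower number on the longer chain of compound 1, as the chain length has been compared here only with hydroxycarbamoyl at the end. From the compounds shown here alone, it is also open whether the amine on the ring matters, which a plain phenyl or a 2-hydroxyphenyl on the same nitrogen would help to settle.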